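The source may report more compounds than this note shows. Statements on the series, on what has been measured and on what is new or still open speak of the compounds shown alone.

Compound 3 `CCC1C(=O)N(C)c2cnc(-n3ccc4cc(C(=O)NC)ccc43)nc2N1c1ccn(C)n1` is measured in an assay for inhibition of serine/threonine-protein kinase PLK2 (Homo sapiens), read by FRET and Z'-LYTE, with a stated time of 1 h (a higher number here means a weaker inhibitor, a lower number a stronger inhibitor), at 218 nM. Among the three compounds measured, compound 3 stands second highest: compound 1 `CCC1C(=O)N(C)c2cnc(-n3ccc4cc(C(=O)NC(C)C)ccc43)nc2N1c1ccn(C)n1` gives 125 nM, a gap within the scatter, while compound 2 `CCC1C(=O)N(C)c2cnc(Nc3ccc(S(=O)(=O)NCCO)cc3)nc2N1c1ccn(C)n1` gives 478 nM, a gap beyond it. Compound 4 `CCC1C(=O)N(C)c2cnc(-n3ccc4cc(F)ccc43)nc2N1c1ccn(C)n1` differs from compound 3 by fluoro in place of methylcarbamoyl on an aromatic carbon. Going by the values given here, the only measured step that touches this position is a 1.7-fold higher number from compound 1 to compound 3 (0.24 log units; within the scatter), which swapped one amide substituent for another and stayed within the scatter; no measured pair removes the methylcarbamoyl group altogether, so this change has no direct precedent here. For compound 4 a modest move toward a higher number is expected, a 1.8-fold higher number from compound 3 to compound 4 (0.26 log units; within the scatter), with wide uncertainty. Compound 4 is estimated at 400 nM, within a range of 120 nM to 1500 nM.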

Compound 4, half-maximal inhibitory concentration: 1500 nM
Compound 4: middle estimate off by 3.8-fold (0.57 log units), on the low side; the measured number falls inside the stated range.
By their numbers in this assay, from the lowest: compounds 1 and 3 (each within the scatter of the next); then compound 2; then compound 4.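

At this aromatic carbon, losing the whole carbamoyl group counts where changing the substituent on its nitrogen did not: the steps to fluoro (a 6.9-fold higher number from compound 3 to compound 4 (0.84 log units; beyond the scatter) and a 12-fold higher number from compound 1 to compound 4 (1.08 log units; beyond the scatter)) both lie beyond the scatter, unlike the step between the two amides (a 1.7-fold higher number from compound 1 to compound 3 (0.24 log units; within the scatter)). Fluoro therefore does not stand in for either amide at this position. Nothing available here explains the size of this loss.

Which part of the amide matters stays open. A carboxylic acid, an amine or a simple primary amide at this carbon would begin to separate the carbonyl from the amide hydrogen.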